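The source may hold more compounds than are shown below. What is called first, only, known or untested is meant among the compounds shown, and "the series" means these compounds.

Compound 2 `CC(=O)N1N=C(c2cc(O)c(O)c([N+](=O)[O-])c2)CC1c1ccoc1` gives 126000 nM in an assay on isolated protein for inhibition of Amine oxidase [flavin-containing] B (Homo sapiens), read by fluorescence; a lower number here means a stronger inhibitor, a higher number a weaker inhibitor. Among the compounds with values here, only one other compound has been measured, compound 1 `CC(=O)N1N=C(c2cc(O)c(O)c([N+](=O)[O-])c2)CC1c1ccc(C#N)cc1`, which gives 83200 nM in this assay, a gap that lies within the scatter. Compound 3 `CC(=O)N1N=C(c2cc(O)c(O)c([N+](=O)[O-])c2)CC1c1cccs1` differs from compound 2 by thiophen-2-yl in place of furan-3-yl on a saturated ring carbon. Within the data shown here, the one step that bears on this, a swap of one aromatic group for another on the same saturated ring carbon, was a 1.5-fold higher number from compound 1 to compound 2 (0.18 log units; within the scatter). An exchange of this kind has so far moved the number little, so compound 3 is expected to show no step beyond the scatter, a 1.3-fold lower number from compound 2 to compound 3 (0.10 log units; within the scatter). Compound 3 is estimated at 100000 nM, within a range from 35000 nM to 300000 nM.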

Compound 3, half-maximal inhibitory concentration: 69200 nM
Compound 3: the middle estimate sits 1.4-fold (0.16 log units) above what was measured; low and high end bracket the measured number.
By their numbers in this assay, from the lowest: compounds 3, 1 and 2 (each within the scatter of the next).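

In this assay the thiophen-2-yl group gives a 1.8-fold lower number from compound 2 to compound 3 (0.26 log units; within the scatter) and a 1.2-fold lower number from compound 1 to compound 3 (0.08 log units; within the scatter), so a sulfur-containing ring joins the other two without any step beyond the scatter. On this saturated ring carbon, 4-cyanophenyl, furan-3-yl and thiophen-2-yl therefore cannot be told apart. No measurement shown offers a reason for this. Still open, going by these compounds, is whether a group that is not an aromatic ring, such as an amine, a carboxylic acid or a longer chain, would move the number beyond the scatter at this carbon.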